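A few compounds are considered here, and "the series" means these few. Any claim that something is new, unique, unknown or untested is made for them only; others in the source may bear on it.

Compound 3 `Cc1ccc(-c2nnc(N3CCN(C(=O)CN4CCN(c5ccccc5)CC4)CC3)nc2-c2ccc(C)cc2)cc1` gives only a limit in an ADME assay on NIH3T3 cells (Mus musculus) for cytotoxicity, read by MTT assay, with a stated time of 24 h; on this read-out lower numbers stand for stronger inhibition and higher numbers for weaker inhibition: compound 3 reads > 914000 nM, a limit of the assay and not a number. The two other values in the set are limits as well. Compound 1 `COc1ccc(N2CCN(CC(=O)N3CCN(c4nnc(-c5ccccc5)c(-c5ccccc5)n4)CC3)CC2)cc1` reads > 910000 nM in this assay, a limit. Compound 2 `O=C(CN1CCN(c2ccc([N+](=O)[O-])cc2)CC1)N1CCN(c2nnc(-c3ccccc3)c(-c3ccccc3)n2)CC1` reads > 886000 nM, also a limit. The one single-site step shown, a step that the two limits leave unreadable from compound 1 to compound 2, stays unreadable because the limit of > 886000 nM in this assay, at which 1 of the 3 values shown sits, and the limit of > 910000 nM in this assay, at which 1 of the 3 values shown sits, cap both ends. For the measured compounds named here, compound 4 `Cc1ccc(-c2nnc(N3CCN(C(=O)CN4CCN(c5ccc(Cl)cc5)CC4)CC3)nc2-c2ccc(C)cc2)cc1` differs from compound 3 by chloro in place of hydrogen on an aromatic carbon, para to a large group; none of the measured steps covers such a change. Starting from the limit of > 914000 nM in this assay, at which 1 of the 3 values shown sits, the step to compound 4 is expected as a number no higher from compound 3 to compound 4 (the limit leaves the size open), no direction beyond the scatter. Compound 4 is estimated at 914000 nM, with a range from 450000 nM to 2000000 nM, most likely again reported as a limit.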

Compound 4, half-maximal inhibitory concentration: 567000 nM
Compound 4: middle estimate off by 1.6-fold (0.21 log units), on the high side, within the range that was stated.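

Compound 4 gives the first number rather than a limit in this assay, with chloro on an aromatic carbon, para to a large group. Phenyl to 4-chlorophenyl gives an at least 1.6-fold lower number from compound 3 to compound 4 (0.20 log units; that floor lies within the scatter). On these data alone, the value of compound 3 is a limit, so only this floor can be read, and the full size of the step stays open.

The step from compound 1 to compound 2 still cannot be read. Open, as far as these compounds go, is whether bromo or an amine at this place also gives a number, and whether chloro does so on the core of compound 1.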